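The source may report more compounds than this note shows. Statements on the series, on what has been measured and on what is new or still open speak of the compounds shown alone.

Compound 2 `Nc1cccc(Cn2cc(CCCCC[C@@H]3SC[C@@H]4NC(=O)N[C@@H]43)nn2)c1` is the starting point of this step. In an assay on isolated protein for inhibition of biotin--protein ligase (Homo sapiens), read by scintillation counting, with a stated time of 10 min (on this read-out higher numbers stand for weaker inhibition and lower numbers for stronger inhibition), compound 2 gives only a limit, > 16000 nM. Two close relatives sit on the same footing. Compound 1 `O=C1N[C@H]2[C@H](CS[C@H]2CCCCCc2cn(Cc3cccc(O)c3)nn2)N1` differs from compound 2 by amino in place of hydroxy on an aromatic carbon. In this assay compound 1 gives only a limit, > 16000 nM. Compound 3 `O=C1N[C@H]2[C@H](CS[C@H]2CCCCCc2cn(Cc3ccc(I)cc3)nn2)N1` likewise gives only a limit in this assay, > 16000 nM. All three values therefore sit at the limit of > 16000 nM in this assay, at which 3 of the 3 values shown sit, and the three steps among them, a step that the two limits leave unreadable from compound 1 to compound 2, a step that the two limits leave unreadable from compound 1 to compound 3 and a step that the two limits leave unreadable from compound 2 to compound 3, are left unreadable in size by the limits on both sides. Compound 4 `O=C1N[C@H]2[C@H](CS[C@H]2CCCCCc2cn(Cc3ccccc3F)nn2)N1` is not yet measured. It differs from compound 2 by 2-fluorophenyl in place of 3-aminophenyl on a saturated chain carbon bound to an aromatic nitrogen. Within the data shown here, none of the measured steps bearing on this change can be read, since each joins two limits, so no direction and no size beyond the scatter can be drawn from them for this assay. Given that compound 2 stands at a limit, compound 4 is expected to stand at or near the same limit, with a step estimated as a step that the limit leaves unreadable from compound 2 to compound 4. The estimate for compound 4 in this assay is 20000 nM, within a range from 6000 nM to 60000 nM.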

Compound 4, inhibition constant: > 16000 nM
Compound 4: only a limit was reported (the forecaster's own chance of this, stated with the estimate: 85%); the middle value does not contradict the limit.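

In this assay compound 4 gives > 16000 nM, which is a limit and not a number. The steps to compound 4 from compound 1, compound 2 and compound 3 cannot be read, since each joins two limits: the limit of > 16000 nM in this assay, at which 4 of the 4 values shown sit.

The compounds shown leave open how strongly any of the four inhibits, and whether exchanging these aromatic groups changes inhibition at all.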